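A few compounds are considered here, and "the series" means these few. Any claim that something is new, unique, unknown or untested is made for them only; others in the source may bear on it.

Measured so far:
compound 1 `CCCn1c(SCc2ccc([N+](=O)[O-])cc2)nc2c1c(=O)[nH]c(=O)n2C` — a functional assay on MGC-803 cells (Homo sapiens) for inhibition, read by MTT assay, with a stated time of 48 h, tested at 20 uM; a lower number here means less inhibition, a higher number more inhibition at the concentration tested (going by the name of the read-out): 19.8%
compound 2 `CCCn1c(SCc2ccc(F)cc2)nc2c1c(=O)[nH]c(=O)n2C` — this assay: 86.5%

For the measured compounds named here, compound 2 stands highest of the two numbers measured, beyond the scatter above the only other value. Going by the values given here, the single measured step is a number 66.7 percentage points higher from compound 1 to compound 2 (beyond the scatter), a fluoro in place of nitro on an aromatic carbon, and it is large. Nothing else is measured in the series.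

The next compound is compound 3 `CCCn1c(SCc2ccc(C(C)(C)C)cc2)nc2c1c(=O)[nH]c(=O)n2C`. It differs from compound 2 by tert-butyl in place of fluoro on an aromatic carbon. Among the compounds with values here, no measured step bears on this change: the one step known concerns nitro against fluoro, and tert-butyl is present in neither measured compound. All that the numbers show is that of the two groups tried at this aromatic carbon, fluoro gave the higher inhibition and nitro the lower, so a third group cannot be placed with confidence on that scale.

With no anchor, the step of a number 26.5 percentage points lower from compound 2 to compound 3 (beyond the scatter) is expected to be a decline of moderate size, with a wide range around it. For compound 3 the estimate in this assay is 60%, from 20% to 92%.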

Compound 3, a percentage reported as inhibition, at one concentration (the size of the read-out at that concentration, not a potency): 10.3%
Beside the measured number, compound 3's estimate is 49.7 percentage points above it; measured number below the stated range.
By their numbers in this assay, from the lowest: compounds 3 and 1 (each within the scatter of the next); then compound 2.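

In this assay, this aromatic carbon now carries three different groups, and the change to tert-butyl gives a number 76.2 percentage points lower from compound 2 to compound 3 (beyond the scatter), a second large step away from fluoro, this time with a group other than nitro. Tert-butyl in place of nitro gives a number 9.5 percentage points lower from compound 1 to compound 3 (within the scatter), so these two groups are not separated, and among the three groups only fluoro, in compound 2, stands apart from the others, with both of its steps beyond the scatter. No measured evidence on the origin of these steps is available.

On these data alone, it remains open whether the high inhibition is particular to fluoro or is shared by other groups at this carbon, such as chloro, bromo, methyl, methoxy or plain hydrogen, and whether fluoro would hold up when moved to another carbon of the same ring. Also open, as far as these compounds go, is how far the picture carries over to a longer chain or a benzyl group on the shared core, and what potency lies behind these readings, which come from a single concentration.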